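The source may report more compounds than this note shows. Statements on the series, on what has been measured and on what is new or still open speak of the compounds shown alone.

Values measured in an ADME assay on HepG2 cells (Homo sapiens) for cytotoxicity, read by neutral red uptake, with a stated time of 24 h; a lower number here means a stronger inhibitor, a higher number a weaker inhibitor:

- Compound 1 `CC(C)c1cc2c3c(c1OC(=O)CCl)OC(=O)[C@@]31CCCC(C)(C)[C@@H]1CC2`: 203000 nM.
- Compound 2 `CCCCCCCCCCCC(=O)Oc1c(C(C)C)cc2c3c1OC(=O)[C@@]31CCCC(C)(C)[C@@H]1CC2`: > 1000000 nM, a limit of the assay.
- Compound 3 `CC(C)c1cc2c3c(c1OC(=O)c1ccccc1)OC(=O)[C@@]31CCCC(C)(C)[C@@H]1CC2`: 510000 nM.

Compound 3 has the higher of the two actual numbers, 510000 nM. Its nearest neighbour is compound 1, at 203000 nM. Compound 2 gives only a limit, > 1000000 nM.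

Compound 4 `CC(C)c1cc2c3c(c1OC(=O)c1cccnc1)OC(=O)[C@@]31CCCC(C)(C)[C@@H]1CC2` keeps the core of compound 3 and has pyridin-3-yl in place of phenyl on a carbonyl carbon.

Two measured steps changed the group on this same carbonyl carbon. The first is modest: a 2.5-fold higher number from compound 1 to compound 3 (0.40 log units; beyond the scatter). The second rests on a limit, and its floor lies within the scatter: an at least 1.9-fold lower number from compound 2 to compound 3 (0.29 log units; that floor lies within the scatter). Neither step swaps one six-membered aromatic ring for another, so both are only loose guides. Changes here have been modest at most in the one fully measured case, and this swap keeps the heavy-atom count unchanged, so no clear shift in either direction is expected.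

The expected change is a 1.3-fold lower number from compound 3 to compound 4 (0.11 log units; within the scatter), an estimated step within the scatter.

For compound 4 the estimate is 400000 nM, with an expected range of 170000 nM to 900000 nM.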

Compound 4, half-maximal inhibitory concentration: 264000 nM
Compound 4: the middle estimate sits 1.5-fold (0.18 log units) above what was measured; measured number inside the range.
By their numbers in this assay, from the lowest: compounds 1, 4 and 3 (each within the scatter of the next, the first and the last beyond it). At a limit, above all of these: compound 2.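

Compound 4 brings a nitrogen into the aromatic ring on this carbonyl carbon, and the swap of phenyl for pyridin-3-yl, which adds a hydrogen-bond acceptor, gives a 1.9-fold lower number from compound 3 to compound 4 (0.29 log units; within the scatter), so in this assay this change cannot be told apart from repeat-measurement noise. Putting pyridin-3-yl in place of chloromethyl gives a 1.3-fold higher number from compound 1 to compound 4 (0.11 log units; within the scatter), so this pair cannot be separated either, even though the phenyl ester did separate from the chloromethyl ester. Only the long chain stands apart, with an at least 3.7-fold lower number from compound 2 to compound 4 (0.57 log units; beyond the scatter), and that step rests on a limit: the limit of > 1000000 nM in this assay, at which 1 of the 4 values shown sits.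

The compounds shown leave open how pyridin-4-yl, or a phenyl ring carrying an amine or a carboxylic acid, would read in this assay. They also leave open where a chain of middling length, such as hexyl, would fall.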